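The source may report more compounds than this note shows. Statements on the series, on what has been measured and on what is new or still open speak of the compounds shown alone.

Measured so far in an assay on CHO cells for displacement of a labelled ligand from histamine receptor H3 (Macaca mulatta); on this read-out lower numbers stand for stronger inhibition and higher numbers for weaker inhibition:
Compound 1 `CC(=O)N1CCCC1C(=O)Nc1ccc(N2CCC(N3CCCC3C)C2)c(C)c1` gives 44.9 nM.
Compound 2 `CC(=O)N1CCCC1C(=O)Nc1ccc(N2CCC(N3CCCC3C)C2)cc1` gives 14.1 nM.
Compound 3 `Cc1cc(N2CC[C@H](N3CCC[C@@H]3C)C2)ccc1NC(=O)C1C(C)(C)C1(C)C` gives 0.55 nM.

Among these three, compound 1 has the highest number. Going by the values given here, the only single-change step recorded is a 3.2-fold lower number from compound 1 to compound 2 (0.50 log units; beyond the scatter); it concerns a methyl on an aromatic carbon, not the group on the carbonyl carbon. Compound 4 `Cc1cc(NC(=O)C2CC2)ccc1N1CCC(N2CCCC2C)C1` differs from compound 1 by cyclopropyl in place of 1-acetylpyrrolidin-2-yl on a carbonyl carbon. Among the compounds with values here, no measured step covers this exact change. Compound 3, which carries a different group on its carbonyl carbon and also differs elsewhere, shows a far lower number than compound 1, so its value is only a hint. A moderate move to a lower number is therefore expected, a 5.6-fold lower number from compound 1 to compound 4 (0.75 log units; beyond the scatter). Compound 4 is estimated at 8 nM, within 2 nM to 30 nM.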

Compound 4, inhibition constant: 17.7 nM
The estimate for compound 4 lay 2.2-fold (0.34 log units) below the measured number; the measured number falls inside the stated range.
By their numbers in this assay, from the lowest: compound 3; then compounds 2 and 4 (each within the scatter of the next); then compound 1.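

Replacing 1-acetylpyrrolidin-2-yl with the smaller cyclopropyl on a carbonyl carbon gives a 2.5-fold lower number from compound 1 to compound 4 (0.40 log units; beyond the scatter) in this assay. Going by these compounds alone, this is the first single-change step at this position, and it shows that the larger group, with its hydrogen-bond acceptor, is not required for binding. Nothing available explains the shift.

Going by these compounds, how an open chain such as isopropyl, or a ring carrying an amine, would behave on this carbonyl carbon stays open. So does whether cyclopropyl would produce a step of similar size on the core of compound 2.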